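Changing the Charged Ring Head at the Chain End

The source may hold more compounds than are shown below. What is called first, only, known or untested is meant among the compounds shown, and "the series" means these compounds.

Compound 1 `CN(C)c1ccc2c(=O)c(C(=O)Nc3cc(F)cc(F)c3)cn(-c3ccc(Cl)c(OCCCCCCC[N+]4(C)CCCC4)c3)c2n1`: 51%
Compound 2 `CC[N+]1(CCCCCCCOc2cc(-n3cc(C(=O)Nc4cc(F)cc(F)c4)c(=O)c4ccc(N(C)C)nc43)ccc2Cl)CCCCC1`: "not active" (no number reported)
Compound 3 `CC[N+]1(CCCCCCCOc2cc(-n3cc(C(=O)Nc4cc(F)cc(F)c4)c(=O)c4ccc(N(C)C)nc43)ccc2Cl)CCCC1`: 46%

In an assay on LX2 cells for inhibition of COL1A1 promoter (Homo sapiens), read by a luciferase reporter, with a stated time of 24 h, tested at 20 uM (on this read-out higher numbers stand for a stronger effect at the one concentration tested and lower numbers for a weaker effect), compound 3 gives 46%, the lowest of the two reported numbers, though its gap to compound 1 is small: a number 5 percentage points lower from compound 1 to compound 3 (within the scatter). Compound 2 returned no number at all. Compound 4 `CN(C)c1ccc2c(=O)c(C(=O)Nc3cc(F)cc(F)c3)cn(-c3ccc(Cl)c(OCCCCCCC[N+](C)(C)C4CCCCC4)c3)c2n1` differs from compound 3 by a group of 9 heavy atoms (8 carbon, 1 nitrogen; one six-membered non-aromatic ring of carbon only) in place of a group of 7 heavy atoms (6 carbon, 1 nitrogen; one five-membered non-aromatic ring with 1 hetero atom), on a saturated chain carbon, seven bonds along the chain from an oxygen on an aromatic ring. Within the data shown here, no measured step exchanges one charged ring head for another of this kind; the only step at the same place, a number 5 percentage points lower from compound 1 to compound 3 (within the scatter), stayed within the scatter, while compound 2, with a larger ring head, was not active. Compound 4 is therefore expected to move a number 4 percentage points lower from compound 3 to compound 4 (within the scatter), not beyond the scatter, with a wide range reflecting the uncertainty. The estimate for compound 4 is 42%, between 15% and 65%.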

Compound 4, a percentage reported as inhibition, at one concentration (the size of the read-out at that concentration, not a potency): 37.6%
The estimate for compound 4 lay 4.4 percentage points above the measured number; the range from low to high includes it.
By their numbers in this assay, from the lowest: compounds 4, 3 and 1 (each within the scatter of the next, the first and the last beyond it).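

In this assay this place now shows its first step beyond the scatter, as a number 13.4 percentage points lower from compound 1 to compound 4 (beyond the scatter) while a number 8.4 percentage points lower from compound 3 to compound 4 (within the scatter) stays within it. With a six-membered non-aromatic ring of carbon only in the group at the chain end, compound 4 still gives a number, whereas compound 2 gave none. Nothing available here explains these differences.

The compounds shown leave open how a trimethylammonium head, with no ring, or a phenyl ring on the charged nitrogen would read at this place. They also leave open whether a longer chain would change the read-out.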